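The source may hold more compounds than are shown below. What is called first, only, known or untested is meant among the compounds shown, and "the series" means these compounds.

Working notes on the series. Of the compounds shown here, three carry a number so far: compound 1 `CC(C)CCn1c(Cn2c(=O)n(C(C)C)c3ccccc32)nc2cc(CNS(C)(=O)=O)ccc21`, compound 2 `CC(C)CCn1c(Cn2c(=O)n(C(C)C)c3ccccc32)nc2ccc(C(=O)O)cc21` and compound 3 `CC(=O)c1ccc2c(c1)nc(Cn1c(=O)n(C)c3ccccc31)n2CCC(C)C`. In an ADME assay on HEp-2 cells (Homo sapiens) for cytotoxicity (a lower number here means that less compound is tolerated, a higher number that more compound is tolerated), compound 1 gives 30800 nM. Compound 2 gives 125000 nM and compound 3 gives 5200 nM. Compound 1 therefore stands second highest of the three numbers: compound 2 sits above it and compound 3 below it, and both gaps are beyond the scatter. For the measured compounds named here, no pair among the measured compounds differs in one place only, so no single-point step has been measured in this assay.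

Compound 4 `CC(C)CCn1c(Cn2c(=O)n(C(C)C)c3ccccc32)nc2cc(C(=O)N(C)C)ccc21` is the next compound, not yet measured. Against compound 1 the change is dimethylcarbamoyl in place of (methanesulfonamido)methyl on an aromatic carbon. Going by the values given here, with no measured step of this kind to lean on, the expectation rests on compound 1 alone because compound 1 gives 30800 nM in this assay. A small downward step a 1.5-fold lower number from compound 1 to compound 4 (0.19 log units; within the scatter) is expected, close to or only just beyond the scatter. Compound 4 is thus estimated at 20000 nM, with a range from 7000 nM to 60000 nM.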

Compound 4, half-maximal cytotoxic concentration: 25600 nM
Compound 4: middle estimate off by 1.3-fold (0.11 log units), on the low side, within the range that was stated.
By their numbers in this assay, from the lowest: compound 3; then compounds 4 and 1 (each within the scatter of the next); then compound 2.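

In this assay, for the compounds shown here, the first single-point step, a 1.2-fold lower number from compound 1 to compound 4 (0.08 log units; within the scatter), shows that dimethylcarbamoyl and (methanesulfonamido)methyl cannot be told apart on this aromatic carbon. Going from a group with 1 hydrogen-bond donor and 2 hydrogen-bond acceptors to one with 0 hydrogen-bond donors and 1 hydrogen-bond acceptor, with sulfur also leaving, therefore opens no gap beyond the scatter at this position. No measurement on hand offers any explanation for the two groups reading alike.

On these data alone, whether an amine or a longer alkyl chain on the same aromatic carbon would also stay within the scatter of compound 1 remains open. The gaps from compound 1 to compound 2 and to compound 3 span more than one place, so they cannot be assigned to any single group.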